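The source may report more compounds than this note shows. Statements on the series, on what has been measured and on what is new or still open speak of the compounds shown alone.

In a functional assay on MOLT-3 cells (Homo sapiens) (a lower number here means a stronger inhibitor, a higher number a weaker inhibitor), compound 3 `CCCCCCCCCSC[C@H](NC(C)=O)C(=O)CCl` gives 6700 nM, the highest of the three numbers, close to compound 1 `CCCCCSC[C@H](NC(C)=O)C(=O)CCl` at 5400 nM and furthest from compound 2 `CCCCCCCSC[C@H](NC(C)=O)C(=O)CCl` at 2500 nM. Compound 4 `CCCCCCCCCCCSC[C@H](NC(C)=O)C(=O)CCl` differs from compound 3 by ethyl in place of hydrogen on a saturated chain carbon, nine bonds along the chain from a sulfur. Among the compounds with values here, two measured steps bear on this change: a 2.2-fold lower number from compound 1 to compound 2 (0.33 log units; beyond the scatter) and a 2.7-fold higher number from compound 2 to compound 3 (0.43 log units; beyond the scatter). The two point in opposite directions, so lengthening the chain shows no settled trend across compounds 1, 2 and 3. The nearer of these two changes along the chain is the rise seen in a 2.7-fold higher number from compound 2 to compound 3 (0.43 log units; beyond the scatter). On that basis the step is expected to be a 1.3-fold higher number from compound 3 to compound 4 (0.13 log units; within the scatter), a somewhat weaker number or none beyond the scatter. Compound 4 is therefore estimated at 9000 nM, within 3500 nM to 25000 nM.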

Compound 4, half-maximal inhibitory concentration: 3000 nM
Compound 4: middle estimate off by 3.0-fold (0.48 log units), on the high side; the measured number lies below the stated range.
By their numbers in this assay, from the lowest: compounds 2, 4, 1 and 3 (each within the scatter of the next, the first and the last beyond it).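

In this assay, the ethyl change at this place lowers the number again, a 2.2-fold lower number from compound 3 to compound 4 (0.35 log units; beyond the scatter), so the earlier rise did not carry on along the chain and the ethyl change now gives a matching drop on two cores: the same change on two cores in this assay, a 2.2-fold lower number (0.33 log units; beyond the scatter) from compound 1 to compound 2 and a 2.2-fold lower number (0.35 log units; beyond the scatter) from compound 3 to compound 4, 1.0-fold (0.01 log units) apart, within the scatter of two such steps Longer extensions separate the compounds little, with a 1.2-fold higher number from compound 2 to compound 4 (0.08 log units; within the scatter) and a 1.8-fold lower number from compound 1 to compound 4 (0.26 log units; within the scatter). The butyl change also repeats closely: the same change on two cores in this assay, a 1.2-fold higher number (0.09 log units; within the scatter) from compound 1 to compound 3 and a 1.2-fold higher number (0.08 log units; within the scatter) from compound 2 to compound 4, 1.0-fold (0.01 log units) apart, within the scatter of two such steps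

On these data alone, whether the up-and-down pattern across compounds 1 to 4 persists with a longer chain remains open. So does the effect of an amine or a carboxylic acid at the chain end.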